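The source may report more compounds than this note shows. Statements on the series, on what has been measured and on what is new or still open speak of the compounds shown alone.

Compound 1, `COc1cc2ncnc(Nc3ccc(B(O)O)cc3)c2cc1OC`: in an assay on isolated protein for inhibition of vascular endothelial growth factor receptor 1 (Homo sapiens), read by ELISA, with a stated time of 20 min (a lower number here means a stronger inhibitor, a higher number a weaker inhibitor), compound 1 gives > 1000 nM, a limit of the assay rather than a number.
Compound 2, `COc1cc2ncnc(Nc3cccc(Cl)c3)c2cc1B1OC(C)(C)C(C)(C)O1`: in this assay compound 2 gives > 1000 nM, again a limit and not a number.

Compound 2 therefore stands nowhere in particular on the numbers shown: its result is only a limit, and the one other value beside it is a limit too, so the two cannot be ordered against each other. Both sit at the limit of > 1000 nM in this assay, at which 2 of the 2 values shown sit.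

Compound 3, `CC1(C)OB(c2ccc3ncnc(Nc4cccc(Cl)c4)c3c2)OC1(C)C`, is the next compound, not yet tested. It differs from compound 2 in one place: hydrogen in place of methoxy on an aromatic carbon. For the measured compounds named here, no measured pair in this set shows what such a change does in this assay, so there is no step to lean on. Given that compound 2 reached only a limit, the change from compound 2 to compound 3 is expected to bring no gain beyond the scatter; compound 3 is expected to land at 3000 nM, with a range of 800 nM to 15000 nM, most likely again reported as a limit, and the expected step is a step that the limit leaves unreadable from compound 2 to compound 3.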

Compound 3, half-maximal inhibitory concentration: > 1000 nM
Compound 3: a limit, no number; the forecaster's own chance of this, stated with the estimate: 75%; the middle value is on the limit's open side.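

In this assay compound 3 gives > 1000 nM, again a limit and not a number. Compound 2 also has only a limit, so no step can be read from compound 2 to compound 3. The compounds shown share one position: the limit of > 1000 nM in this assay, at which 3 of the 3 values shown sit. They leave open how strongly each inhibits and what hydrogen in place of methoxy does to that inhibition.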